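The source may hold more compounds than are shown below. What is called first, only, known or untested is meant among the compounds shown, and "the series" means these compounds.

In a functional assay on DLD-1 cells (Homo sapiens) for antiproliferative activity, read by CellTiter-Glo, with a stated time of 72 h (on this read-out higher numbers stand for weaker inhibition and lower numbers for stronger inhibition), compound 1 `CC1CCN(C2CCN(S(=O)(=O)c3cccc(Br)c3)CC2)CC1` gives 3.2 nM. Compound 2 `CC1CCN(C2CCN(S(=O)(=O)c3cn(C)cn3)CC2)CC1` gives > 5000 nM in this assay, which is a limit of the assay and not a number (the limit of > 5000 nM in this assay, at which 1 of the 3 values shown sits). Compound 3 `Cc1cccc(S(=O)(=O)N2CCC(N3CCC(C)CC3)CC2)c1` gives 25 nM in this assay, the highest of the two numbers shown; the nearest number is compound 1, the step being a 7.8-fold higher number from compound 1 to compound 3 (0.89 log units; beyond the scatter), and toward compound 2 only the limit separates them an at least 200-fold lower number from compound 2 to compound 3 (2.30 log units; beyond the scatter).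

Compound 4 `CC1CCN(C2CCN(S(=O)(=O)c3cncc(Br)c3)CC2)CC1` is not yet measured. The change: 5-bromopyridin-3-yl in place of 3-methylphenyl on a sulfonyl sulfur. Among the measured compounds shown here, two measured steps bear on it. The bromo returns, and since the step of a 7.8-fold higher number from compound 1 to compound 3 (0.89 log units; beyond the scatter) accompanied methyl in place of bromo, the reverse suggests a modest gain. The ring also takes up a nitrogen; the only heteroaryl measured is the 1-methyl-1H-imidazol-4-yl of compound 2, where an at least 1500-fold higher number from compound 1 to compound 2 (3.19 log units; beyond the scatter) was a large loss, but that is a different ring from 5-bromopyridin-3-yl. The expected step in this assay is therefore a 2.5-fold lower number from compound 3 to compound 4 (0.40 log units; beyond the scatter), a modest lower number with wide uncertainty. Compound 4 is estimated at 10 nM in this assay, between 2 nM and 50 nM.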

Compound 4, half-maximal inhibitory concentration: > 5000 nM
Compound 4: no number, only a limit; the forecaster's own chance of this, stated with the estimate: 3%; at least 500-fold (2.69 log units) between middle value and limit.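

Keeping the bromo and placing one nitrogen in the ring gives an at least 1500-fold higher number from compound 1 to compound 4 (3.19 log units; beyond the scatter) in this assay, so the loss seen earlier with 1-methyl-1H-imidazol-4-yl is not confined to that ring. Against 3-methylphenyl, the change gives an at least 200-fold higher number from compound 3 to compound 4 (2.30 log units; beyond the scatter), so the bromo does not secure activity on its own; among the four compounds, the two carbon-only rings give numbers and the two rings with hetero atoms do not. Compound 4 gives a limit of the assay and not a number, which leaves its step to compound 2 unreadable: the limit of > 5000 nM in this assay, at which 2 of the 4 values shown sit.

From the compounds shown here alone, whether a 3-chlorophenyl or 3-methoxyphenyl group on the sulfonyl sulfur gives a number in this assay stays open. Also open, going by these compounds, is whether any ring with a hetero atom, such as a thiophene, can hold activity here.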